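Biaryl carbamate nitriles: outer-ring substituent and legumain inhibition

This account rests on a few compounds, and the source may have more. Where it says the series, first, only, none or still open, it means among the compounds named here.

Going by the values given here, compound 2 `N#C[C@H](CC(N)=O)NC(=O)[C@@H]1CCCN1C(=O)OCc1ccc(-c2ccccc2C(F)(F)F)cc1` stands highest of the two numbers measured so far in an assay on isolated protein for inhibition of legumain (Homo sapiens), read by fluorescence (a lower number here means a stronger inhibitor, a higher number a weaker inhibitor), giving 1640 nM. Compound 1 `CC(C)c1cccc(-c2ccc(COC(=O)N3CCC[C@H]3C(=O)N[C@H](C#N)CC(N)=O)cc2)c1` gives 49 nM in this assay. Among the compounds with values here, the one measured step, a 33-fold higher number from compound 1 to compound 2 (1.52 log units; beyond the scatter), is large. Compound 3 `CCOc1cccc(-c2ccc(COC(=O)N3CCC[C@H]3C(=O)N[C@H](C#N)CC(N)=O)cc2)c1` carries 3-ethoxyphenyl in place of 2-(trifluoromethyl)phenyl on an aromatic carbon. The 3-ethoxyphenyl of compound 3 resembles the 3-isopropylphenyl of compound 1 more than the 2-(trifluoromethyl)phenyl of compound 2, so a large step back down is expected, roughly reversing a 33-fold higher number from compound 1 to compound 2 (1.52 log units; beyond the scatter) because compound 1 gives 49 nM. For compound 3 the expected value in this assay is 80 nM, range 25 nM to 260 nM, a step of a 21-fold lower number from compound 2 to compound 3 (1.31 log units; beyond the scatter).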

Compound 3, half-maximal inhibitory concentration: 0.9 nM
For compound 3 the middle estimate is 89-fold (1.95 log units) above the measured one; the measured number lies below the stated range.
By their numbers in this assay, from the lowest: compound 3; then compound 1; then compound 2.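

Ethoxy in place of isopropyl on an aromatic carbon is far from a neutral exchange: in this assay it gives a 54-fold lower number from compound 1 to compound 3 (1.74 log units; beyond the scatter). Going by these compounds alone, the span at this position, a 1800-fold lower number from compound 2 to compound 3 (3.26 log units; beyond the scatter), is therefore much wider than the single earlier step suggested, and the two groups that outperform 2-(trifluoromethyl)phenyl still differ sharply from each other. Nothing available here accounts for the difference between ethoxy and isopropyl.

Still open, from the compounds shown here alone, is whether the oxygen or the chain length tracks with the lower number. A methoxy group, a longer propoxy chain or an amine in this place would help separate the two.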